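This account rests on a few compounds, and the source may have more. Where it says the series, first, only, none or still open, it means among the compounds named here.

Measured in a functional assay on HepG2 cells (Homo sapiens) for cytotoxicity, read by MTT assay, with a stated time of 24 h; a higher number here means a weaker inhibitor, a lower number a stronger inhibitor:

compound 1 `O=C1/C(=C/c2cccnc2)CN(S(=O)(=O)c2ccc(Br)cc2)C/C1=C\c1ccccc1C(F)(F)F` gives 2730 nM
compound 2 `N#Cc1ccc(S(=O)(=O)N2C/C(=C\c3cccnc3)C(=O)/C(=C/c3ccccc3C(F)(F)F)C2)cc1` gives 5060 nM
compound 3 `O=C1/C(=C/c2ccncc2)CN(S(=O)(=O)c2ccc(Br)cc2)C/C1=C\c1ccccc1C(F)(F)F` gives 14500 nM

Compound 1 and compound 2 share one core and differ in a single place, (cyano in place of bromo on an aromatic carbon). The step of a 1.9-fold higher number from compound 1 to compound 2 (0.27 log units; within the scatter). Compound 3 carries a different core from compound 1, the two differing as pyridin-4-yl in place of pyridin-3-yl on a double-bonded chain carbon bound to a double-bonded ring carbon, and the step of a 5.3-fold higher number from compound 1 to compound 3 (0.73 log units; beyond the scatter). Compound 3 has the highest number of the three measured compounds, beyond the scatter from each of the other two.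

Compound 4 `N#Cc1ccc(S(=O)(=O)N2C/C(=C\c3ccncc3)C(=O)/C(=C/c3ccccc3C(F)(F)F)C2)cc1` has not yet been measured. It stands to compound 3 as compound 2 stands to compound 1: cyano in place of bromo on an aromatic carbon. The two place descriptions read the same word for word, so this is the same change, made on the core of compound 3 rather than that of compound 1. Within the data shown here, the only guide is the single earlier step, which lay within the scatter; a step of about that size is expected, a 1.8-fold higher number from compound 3 to compound 4 (0.25 log units; within the scatter), resting on a 1.9-fold higher number from compound 1 to compound 2 (0.27 log units; within the scatter). Among the measured compounds shown here, since only one instance of the change is available and the core differs, the range is kept wide. Compound 4 is estimated at 26000 nM in this assay, between 10000 nM and 65000 nM.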

Compound 4, half-maximal inhibitory concentration: 5920 nM
The estimate for compound 4 lay 4.4-fold (0.64 log units) above the measured number, outside the stated range (below it).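

In this assay, cyano in place of bromo does not carry over from one core to the other, with a 2.4-fold lower number from compound 3 to compound 4 (0.39 log units; beyond the scatter) on the pyridin-4-yl core set against the earlier step on the pyridin-3-yl core: the same change on two cores in this assay, a 1.9-fold higher number (0.27 log units; within the scatter) from compound 1 to compound 2 and a 2.4-fold lower number (0.39 log units; beyond the scatter) from compound 3 to compound 4, 4.5-fold (0.66 log units) apart, beyond the scatter of two such steps

The pyridine change does not carry over either, with a 1.2-fold higher number from compound 2 to compound 4 (0.07 log units; within the scatter) in the cyano compounds set against the earlier step in the bromo compounds: the same change on two cores in this assay, a 5.3-fold higher number (0.73 log units; beyond the scatter) from compound 1 to compound 3 and a 1.2-fold higher number (0.07 log units; within the scatter) from compound 2 to compound 4, 4.5-fold (0.66 log units) apart, beyond the scatter of two such steps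

Among these compounds, these four compounds therefore show that neither change can be treated as a fixed increment, since the size of each step depends on the group at the other place, but with only two instances of each change they do not show why this happens or how far it extends to other groups.

On these data alone, it remains open whether an amine or a methoxy group in place of bromo would follow the cyano compounds or the bromo compounds. As far as these compounds go, it is also open whether pyridin-2-yl, or a chloro group in place of trifluoromethyl, would show the same dependence.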